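Propargyloxy in place of allyloxy on the shared core

A few compounds are considered here, and "the series" means these few. Any claim that something is new, unique, unknown or untested is made for them only; others in the source may bear on it.

Measured compounds:
Compound 1, `Nc1nc(-c2ccc(O)cc2)cn2c(=O)n(-c3ccccc3)nc12`, 45 nM in an assay on cells for displacement of a labelled ligand from adenosine receptor A1 (Homo sapiens), read by scintillation counting, with a stated time of 3 h; a lower number here means a stronger inhibitor, a higher number a weaker inhibitor.
Compound 2, `C=CCOc1ccc(-c2cn3c(=O)n(-c4ccccc4)nc3c(N)n2)cc1`, "not determined" (no result reported) in this assay.

From the compounds shown here alone, compound 2 stands without a number: in this assay compound 2 gives "not determined" (no result reported), so its position on the scale is unknown. Among the measured compounds shown here, the only number available comes from compound 1, which gives 45 nM in this assay.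

Compound 3, `C#CCOc1ccc(-c2cn3c(=O)n(-c4ccccc4)nc3c(N)n2)cc1`, is not yet measured. It differs from compound 2 in one place: ethynyl in place of vinyl on a saturated chain carbon bound to an oxygen on an aromatic ring. For the measured compounds named here, since compound 2 carries no value, no step can be computed, and the size of the change in this assay cannot be anchored. A difference of this kind is expected to move the number little, if at all, beyond the scatter.

Resting on compound 1 and its 45 nM as the only reference, compound 3 is estimated at 90 nM, with a range from 20 nM to 500 nM.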

Compound 3, inhibition constant: > 30000 nM
Compound 3 ended at the assay's limit; the forecaster's own chance of this, stated with the estimate: 10%; middle value at least 330-fold (2.52 log units) from the limit.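

In this assay, propargyl in place of hydrogen on the oxygen on the aromatic ring gives an at least 660-fold higher number from compound 1 to compound 3 (2.82 log units; beyond the scatter). Among the compounds shown here, the result for compound 3 is a limit of the assay and not a number: the limit of > 30000 nM in this assay, at which 1 of the 3 values shown sits. This is the first sign that what is carried on this oxygen matters in this assay, and the change is large, well beyond what the opening comparison could anchor.

From the compounds shown here alone, compound 2 carries no value, and its step to compound 3 cannot be read, so it stays open whether the loss goes with the triple bond of propargyl or with any chain on this oxygen, allyl included. Also open, going by these compounds, is how a methyl group or a longer saturated chain on the same oxygen would read in this assay.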